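This account rests on a few compounds, and the source may have more. Where it says the series, first, only, none or still open, it means among the compounds named here.

Measured so far in a functional assay on CCRF-CEM cells (Homo sapiens) for cytotoxicity; on this read-out higher numbers stand for weaker inhibition and lower numbers for stronger inhibition:
Compound 1 `O=C(/C=C/C(=O)N1C/C(=C\c2ccccc2)C(=O)/C(=C/c2ccccc2)C1)Nc1ccc(Cl)c(Cl)c1` gives 350 nM.
Compound 2 `O=C(/C=C/C(=O)N1C/C(=C\c2ccccc2)C(=O)/C(=C/c2ccccc2)C1)Nc1ccc([N+](=O)[O-])cc1` gives 40000 nM.
Compound 3 `Cc1ccc(NC(=O)/C=C/C(=O)N2C/C(=C\c3ccccc3)C(=O)/C(=C/c3ccccc3)C2)cc1C` gives 7100 nM.

Among these three numbers compound 3 stands second highest: the step of a 5.6-fold lower number from compound 2 to compound 3 (0.75 log units; beyond the scatter) separates it from the highest, while a 20-fold higher number from compound 1 to compound 3 (1.31 log units; beyond the scatter) separates it from the lowest, compound 1. Compound 4 `O=C(/C=C/C(=O)N1C/C(=C\c2ccccc2)C(=O)/C(=C/c2ccccc2)C1)Nc1ccc(Cl)cc1` is still unmeasured; the change from compound 3 is 4-chlorophenyl in place of 3,4-dimethylphenyl on an amide-type nitrogen. The step that bears most on it is a 20-fold higher number from compound 1 to compound 3 (1.31 log units; beyond the scatter), since compound 1 carries a ring with two chlorines where compound 4 carries one. A lower number than compound 3 is therefore expected, of roughly a 4.7-fold lower number from compound 3 to compound 4 (0.68 log units; beyond the scatter), though less far than compound 1 reached. The estimate for compound 4 is 1500 nM, with a range of 400 nM to 6000 nM.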

Compound 4, half-maximal inhibitory concentration: 840 nM
Beside the measured number, compound 4's estimate is 1.8-fold (0.25 log units) above it, within the range that was stated.
By their numbers in this assay, from the lowest: compound 1; then compound 4; then compound 3; then compound 2.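

In this assay, the group on the amide-type nitrogen matters even when a single substituent on the ring changes: chloro in place of nitro gives a 48-fold lower number from compound 2 to compound 4 (1.68 log units; beyond the scatter), and 4-chlorophenyl in place of 3,4-dimethylphenyl gives an 8.5-fold lower number from compound 3 to compound 4 (0.93 log units; beyond the scatter). Losing the second chlorine costs far less, with a 2.4-fold higher number from compound 1 to compound 4 (0.38 log units; beyond the scatter), so one chlorine already brings the number close to that of the dichlorinated ring. Nothing shown explains why these groups differ. Still open, as far as these compounds go, is how an unsubstituted phenyl ring, or one carrying a methoxy or an amino group, would compare on this nitrogen.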